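The source may report more compounds than this note shows. Statements on the series, on what has been measured and on what is new or still open speak of the compounds shown alone.

The measured compounds are compound 1, `CC(O)(CSc1cc(C(F)(F)F)cc(C(F)(F)F)c1)C(=O)Nc1cccc(S(F)(F)(F)(F)F)c1`, compound 2, `CC(O)(COc1cccc(S(F)(F)(F)(F)F)c1)C(=O)Nc1ccc(C(F)(F)F)cc1`, and compound 3, `CC(O)(COc1cccc(C(F)(F)C(F)(F)F)c1)C(=O)Nc1ccc(C(F)(F)F)cc1`. In a functional assay on CWR22R cells (Homo sapiens) for antiproliferative activity, read by propidium iodide staining, with a stated time of 96 h (a lower number here means a stronger inhibitor, a higher number a weaker inhibitor), compound 1 gives 4400 nM, compound 2 gives 15800 nM, and compound 3 gives 3600 nM.

The change between compound 2 and compound 3 is a group of 7 heavy atoms (2 carbon, 5 fluorine; no ring) in place of a group of 6 heavy atoms (5 fluorine, 1 sulfur; no ring), on an aromatic carbon. It produced a 4.4-fold lower number from compound 2 to compound 3 (0.64 log units; beyond the scatter). The values of compound 1 and compound 3 lie within the scatter of each other, while compound 1 and compound 2 differ beyond it; how the core of compound 1 differs from that of compound 2 is not broken down here.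

Compound 4, `CC(O)(CSc1cc(C(F)(F)F)cc(C(F)(F)F)c1)C(=O)Nc1cccc(C(F)(F)C(F)(F)F)c1`, has not yet been measured in this assay. Compound 4 differs from compound 1 as follows: a group of 7 heavy atoms (2 carbon, 5 fluorine; no ring) in place of a group of 6 heavy atoms (5 fluorine, 1 sulfur; no ring), on an aromatic carbon. This is the same change seen between compound 2 and compound 3, and it occurs twice among the compounds shown, with only the one measured instance to rest on.

For the measured compounds named here, because compound 1 gives 4400 nM and the single earlier instance gave a 4.4-fold lower number from compound 2 to compound 3 (0.64 log units; beyond the scatter), compound 4 is expected to show a 3.7-fold lower number from compound 1 to compound 4 (0.56 log units; beyond the scatter), tempered by the unbroken-down core difference. Compound 4 is therefore estimated at 1200 nM, between 500 nM and 3500 nM.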

Compound 4, half-maximal inhibitory concentration: 4200 nM
Estimate against measurement, compound 4: 3.5-fold (0.54 log units) below; the whole stated range lies below it.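

Carried to a second core in this assay, the exchange of the group of fluorine and sulfur for 1,1,2,2,2-pentafluoroethyl gave a 1.0-fold lower number from compound 1 to compound 4 (0.02 log units; within the scatter). The step seen on the first core did not carry over in size to the second: the same change on two cores in this assay, a 4.4-fold lower number (0.64 log units; beyond the scatter) from compound 2 to compound 3 and a 1.0-fold lower number (0.02 log units; within the scatter) from compound 1 to compound 4, 4.2-fold (0.62 log units) apart, beyond the scatter of two such steps. This shows that, in this series, the effect of the change on one core cannot simply be transferred to another, but two pairs do not show which of the differences between the cores is responsible, nor what the change would do on a third core.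

No pair shown exchanges the sulfur link of compound 1 for an oxygen link with all else kept, so the part played by each difference between the cores remains open. Also open, going by these compounds, is how a different group in the same place, such as a nitrile or a longer fluorinated chain, would behave on either core.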